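Swapping chloro for methoxy on a second benzothiazole amide

The compounds below may be only part of what the source reports. "The series", "measured", "known", "first", "only" and "open" are said of these compounds alone.

Measured so far:
compound 1 `O=C(Nc1nc2ccc(Cl)cc2s1)c1cn(-c2ccccc2)nc1-c1ccc(F)cc1`: 3170 nM
compound 2 `COc1ccc2nc(NC(=O)c3cn(-c4ccccc4)nc3-c3ccc(F)cc3)sc2c1`: 12800 nM
compound 3 `COc1ccc(-c2nn(-c3ccccc3)cc2C(=O)Nc2nc3ccc(Cl)cc3s2)cc1`: 6510 nM

In a functional assay on PC-3 cells (Homo sapiens) for cytotoxicity, read by MTT assay, with a stated time of 72 h (a lower number here means a stronger inhibitor, a higher number a weaker inhibitor), compound 1 gives 3170 nM. Changing it to compound 2 by methoxy in place of chloro on an aromatic carbon makes a 4.0-fold higher number from compound 1 to compound 2 (0.61 log units; beyond the scatter). Compound 3 differs from compound 1 by methoxy in place of fluoro on an aromatic carbon, and that gives a 2.1-fold higher number from compound 1 to compound 3 (0.31 log units; beyond the scatter). Compound 4 `COc1ccc(-c2nn(-c3ccccc3)cc2C(=O)Nc2nc3ccc(OC)cc3s2)cc1` is not yet measured; it differs from compound 3 by methoxy in place of chloro on an aromatic carbon, the same change seen from compound 1 to compound 2, and the two changes sit in the same place. The expectation therefore rests on compound 1 and compound 2: the step in this assay from compound 3 to compound 4 is estimated as a 3.7-fold higher number from compound 3 to compound 4 (0.57 log units; beyond the scatter), about as large as a 4.0-fold higher number from compound 1 to compound 2 (0.61 log units; beyond the scatter). On that basis compound 4 is expected to give 24000 nM, likely between 10000 nM and 55000 nM.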

Compound 4, half-maximal inhibitory concentration: 13500 nM
Compound 4: the middle estimate sits 1.8-fold (0.25 log units) above what was measured; measured number inside the range.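

In this assay, going from 6-chloro-1,3-benzothiazol-2-yl to 6-methoxy-1,3-benzothiazol-2-yl gives a 2.1-fold higher number from compound 3 to compound 4 (0.32 log units; beyond the scatter), and this agrees with the earlier step for the same change: the same change on two cores in this assay, a 4.0-fold higher number (0.61 log units; beyond the scatter) from compound 1 to compound 2 and a 2.1-fold higher number (0.32 log units; beyond the scatter) from compound 3 to compound 4, 1.9-fold (0.29 log units) apart, within the scatter of two such steps. Methoxy in place of fluoro gives a 1.1-fold higher number from compound 2 to compound 4 (0.02 log units; within the scatter), and this also agrees with its earlier counterpart: the same change on two cores in this assay, a 2.1-fold higher number (0.31 log units; beyond the scatter) from compound 1 to compound 3 and a 1.1-fold higher number (0.02 log units; within the scatter) from compound 2 to compound 4, 1.9-fold (0.29 log units) apart, within the scatter of two such steps. Each change therefore carries across these four compounds, but two steps per change are a small sample and do not show that it would hold on any other core.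

Still open, from the compounds shown here alone, is whether other groups in place of the chloro, such as an amine or a carboxylic acid, would behave as methoxy does. The same question applies to a longer chain in place of the fluoro.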